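Stereoisomer series: colon half-life sits at the assay limit

The compounds below may be only part of what the source reports. "The series", "measured", "known", "first", "only" and "open" are said of these compounds alone.

Three stereoisomers of the shared core have been run in an ADME assay on Colon (Mus musculus, strain C57BL/6) for metabolic stability, read by HPLC, with a stated time of 12 h; on this read-out higher numbers stand for a longer-lived compound and lower numbers for a shorter-lived compound. Compound 1 `O=C(O)[C@H](CO)NC(=O)[C@H]1C[C@H](O)CN1` returns only the assay limit, > 12 h, not a number. Compound 2 `O=C(O)[C@H](CO)NC(=O)[C@H]1C[C@@H](O)CN1` likewise gives only the limit, > 12 h. Compound 3 `O=C(O)[C@H](CO)NC(=O)[C@@H]1C[C@H](O)CN1` also reaches only the limit, > 12 h, so its standing in the series is simply that all three values shown are limits and no ordering among them can be read. The steps between them are accordingly unreadable: a step that the two limits leave unreadable from compound 1 to compound 2, a step that the two limits leave unreadable from compound 1 to compound 3 and a step that the two limits leave unreadable from compound 2 to compound 3, because of the limit of > 12 h in this assay, at which 3 of the 3 values shown sit.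

The next compound, compound 4 `O=C(O)[C@@H](CO)NC(=O)[C@H]1C[C@H](O)CN1`, again alters only configuration: the two compounds have the same atoms and bonds and differ only in configuration as drawn: 2 of 3 stereo elements differ; a stereocentre at a saturated chain carbon is drawn S in compound 3 and R in compound 4; a stereocentre at a saturated ring carbon is drawn S in compound 3 and R in compound 4. Within the data shown here, the steps that bear on it are the three unreadable ones above, each an inversion at a ring carbon; none yields a size, and none of those inversions moved a value off the limit in this assay. No step beyond the scatter is therefore expected for compound 4, and a step that the limit leaves unreadable from compound 3 to compound 4 is the expected step. Compound 4 is estimated at 24 h, with a range from 10 h to 60 h.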

Compound 4, half-life in the Mus musculus assay: > 12 h
Compound 4 was reported as a limit; the forecaster's own chance of this, stated with the estimate: 80%; the middle value is on the limit's open side.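

No new step can be read between compound 4 and compound 1, compound 2 or compound 3 in the Mus musculus assay: the limit of > 12 h in the Mus musculus assay, at which 4 of the 4 values shown sit.

In a physicochemical assay for metabolic stability, read by HPLC, in phosphate buffer, with a stated time of 12 h, at pH 7.2 (a lower number here means that the compound disappears faster, a higher number that the compound lasts longer), compound 3 gives > 12 h, a limit and not a number. In the physicochemical assay compound 4 gives > 12 h, also a limit.

The compounds shown leave open how these stereoisomers rank on half-life, and whether configuration changes it at all.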